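Substituent swap on the shared core: fluoro to methyl

This account rests on a few compounds, and the source may have more. Where it says the series, first, only, none or still open, it means among the compounds named here.

Compound 1 `O=C(O)c1ccn(Cc2cc(Br)ccc2OCc2ccccc2)n1` is the unsubstituted parent of the set; in a functional assay on CHO-K1 cells for antagonist activity at prostaglandin E2 receptor EP1 subtype (Homo sapiens), read by FLIPR (a higher number here means a weaker inhibitor, a lower number a stronger inhibitor), compound 1 gives 55 nM. Compound 3 `O=C(O)c1nn(Cc2cc(Br)ccc2OCc2ccccc2)cc1F` carries a fluoro on the core; in this assay compound 3 gives 692 nM, the highest of the two numbers recorded, with compound 1 the nearest, since a 13-fold higher number from compound 1 to compound 3 (1.10 log units; beyond the scatter). Compound 2 `CC(=O)Nc1cc(C(=O)O)nn1Cc1cc(Br)ccc1OCc1ccccc1` carries an acetamido instead, and in this assay compound 2 gives only a limit, < 2000 nM. The step that the limit leaves unreadable from compound 1 to compound 2 therefore cannot be sized; the limit is recorded as the limit of < 2000 nM in this assay, at which 1 of the 3 values shown sits.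

Compound 4 `Cc1cn(Cc2cc(Br)ccc2OCc2ccccc2)nc1C(=O)O` is the next entry: methyl in place of fluoro on an aromatic carbon. Among the measured compounds shown here, the only measured step that bears on it directly is a 13-fold higher number from compound 1 to compound 3 (1.10 log units; beyond the scatter), which showed that putting a substituent on this carbon weakened inhibition. For the measured compounds named here, no measured pair shows what exchanging one substituent for another at the same carbon does, so the direction of the change is open. A move within the scatter of compound 3 is the expectation, with some chance of a further loss. Compound 4 is expected to give 700 nM in this assay, within 200 nM to 3000 nM. That estimate means an expected step of a 1.0-fold higher number from compound 3 to compound 4 (0.00 log units; within the scatter), not beyond the scatter.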

Compound 4, inhibition constant: 1350 nM
For compound 4 the middle estimate is 1.9-fold (0.29 log units) below the measured one; the range from low to high includes it.
By their numbers in this assay, from the lowest: compound 1; then compounds 3 and 4 (each within the scatter of the next).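

The exchange of fluoro for methyl on this aromatic carbon, next to the ring atom that bears a carboxy group, is a 2.0-fold higher number from compound 3 to compound 4 (0.29 log units; within the scatter), so in this assay these two substituents are not separated. Measured against the unsubstituted parent, the methyl gives a 25-fold higher number from compound 1 to compound 4 (1.39 log units; beyond the scatter), which means the large loss is no longer tied to fluoro alone: across compound 3 and compound 4, both substituents on this carbon sit well away from compound 1, and neither of the two goes against that pattern. Nothing measured in this set gives a reason for the loss or for the closeness of the two substituents.

On these data alone, what an amine or a longer chain on this carbon would give in this assay remains open, and so does whether any group here can return to the level of compound 1 at 55 nM. As far as these compounds go, compound 2 gives only a limit, < 2000 nM, so its step cannot be read and the effect of an acetamido on the shared core also stays open.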